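Swapping bromo for cyclopropyl on a slowly cleared compound

The source may report more compounds than this note shows. Statements on the series, on what has been measured and on what is new or still open speak of the compounds shown alone.

Values in an ADME assay on microsomes from liver (Homo sapiens) for metabolic stability, read by LC-MS (on this read-out higher numbers stand for fast clearance and lower numbers for slow clearance), for the measured compounds

Compound 1 `FC(F)(F)c1nccc(N[C@H]2CC[C@@H](Nc3cnc4ccccc4c3)CC2)n1` gives 5.2 mL.min-1.g-1
Compound 2 `FC(F)(F)c1nccc(N[C@H]2CC[C@@H](Nc3ncnc4sccc34)CC2)n1` gives 22 mL.min-1.g-1
Compound 3 `FC(F)(F)c1nccc(N[C@H]2CC[C@@H](Nc3ccc4nnc(Br)n4n3)CC2)n1` gives < 3 mL.min-1.g-1 as a limit of the assay, not a number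

Compound 3 stands at the limit of < 3 mL.min-1.g-1 in this assay, at which 1 of the 3 values shown sits, and so has no exact number. Compound 4 `FC(F)(F)c1nccc(N[C@H]2CC[C@@H](Nc3ccc4nnc(C5CC5)n4n3)CC2)n1` carries cyclopropyl in place of bromo on an aromatic carbon and has not yet been measured. For the measured compounds named here, no measured pair shows this swap directly. A small rise in this assay is expected, possibly none beyond the scatter, and compound 4 may again report only a limit. The estimated change is an at least 1.5-fold higher number from compound 3 to compound 4 (0.17 log units; that floor lies within the scatter) and remains uncertain. For compound 4 the expected value is 4.5 mL.min-1.g-1 with an estimated range from 2.5 mL.min-1.g-1 to 12 mL.min-1.g-1 in this measurement.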

Compound 4, intrinsic clearance in microsomes: < 3 mL.min-1.g-1
Compound 4 was reported as a limit (the forecaster's own chance of this, stated with the estimate: 35%); at least 1.5-fold (0.17 log units) between middle value and limit.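

Compound 3 and compound 4 both report only a limit in this assay, not a number, so no step between them can be read: the limit of < 3 mL.min-1.g-1 in this assay, at which 2 of the 4 values shown sit.

The compounds shown leave open how fast either compound is actually cleared, and whether cyclopropyl in place of bromo changes that at all.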